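This account rests on a few compounds, and the source may have more. Where it says the series, first, only, none or still open, it means among the compounds named here.

In a functional assay on WM164 cells (Homo sapiens) for antiproliferative activity, read by sulforhodamine B assay, with a stated time of 48 h; on this read-out lower numbers stand for stronger inhibition and higher numbers for weaker inhibition:
- compound 1 `CCCCCCCCCCCCCCNC(=O)[C@@H]1CSC(c2ccc(NC(C)=O)cc2)N1`: 600 nM
- compound 2 `CCCCCCCCCCCCCCCCCNC(=O)[C@@H]1CSC(c2ccc(NC(C)=O)cc2)N1`: 2400 nM
- compound 3 `CCCCCCCCC/C=C/CCCCCCCNC(=O)[C@@H]1CSC(c2ccc(NC(C)=O)cc2)N1`: 1400 nM

Compound 3 stands in the upper part of these numbers. The record shows a 1.7-fold lower number from compound 2 to compound 3 (0.23 log units; within the scatter), while a 2.3-fold higher number from compound 1 to compound 3 (0.37 log units; beyond the scatter). Compound 4 `CCCCCCCCC/C=C\CCCCCCCNC(=O)[C@@H]1CSC(c2ccc(NC(C)=O)cc2)N1` is the next to be read: the two compounds have the same atoms and bonds; at least one stereo element is drawn with a configuration in one of them and without one in the other: 1 of 3 stereo elements differ; a double bond is drawn E in compound 3 and Z in compound 4. For the measured compounds named here, no measured pair isolates a double bond drawn E against one drawn Z. The nearest evidence is the chain changes, which gave only modest steps, namely a 4.0-fold higher number from compound 1 to compound 2 (0.60 log units; beyond the scatter) and the step to compound 3 above. A change that keeps every atom and bond is therefore expected to give no step beyond the scatter in this assay. The expected step is a 1.2-fold lower number from compound 3 to compound 4 (0.07 log units; within the scatter). For compound 4 the estimated value is 1200 nM, with an expected range of 500 nM to 2900 nM.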

Compound 4, half-maximal inhibitory concentration: 1000 nM
Compound 4: the middle estimate sits 1.2-fold (0.08 log units) above what was measured, within the range that was stated.
By their numbers in this assay, from the lowest: compounds 1, 4, 3 and 2 (each within the scatter of the next, the first and the last beyond it).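

In this assay, for the compounds shown here, swapping the double bond from E to Z leaves the result within the scatter, the first direct reading of this change: a 1.4-fold lower number from compound 3 to compound 4 (0.15 log units; within the scatter). Against the two saturated chains the outcome splits, a 1.7-fold higher number from compound 1 to compound 4 (0.22 log units; within the scatter), but a 2.4-fold lower number from compound 2 to compound 4 (0.38 log units; beyond the scatter), whereas the E-drawn chain had stayed within the scatter of that longer saturated chain. This reading of the double bond carries one caution: the fact that one of compounds 3 and 4 is drawn with a defined configuration and the other without, at the place where they differ

The compounds shown leave open whether the double bond's geometry matters at another place along the chain. They also leave open how a shorter chain, or a chain ending in a carboxylic acid or an amine, would read here.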